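A flat series meets 3-bromo-4-hydroxyphenyl

This account rests on a few compounds, and the source may have more. Where it says the series, first, only, none or still open, it means among the compounds named here.

Measured in a functional assay on HepG2 cells (Homo sapiens) for cytotoxicity, read by MTT assay, with a stated time of 72 h; on this read-out higher numbers stand for weaker inhibition and lower numbers for stronger inhibition:
compound 1 `O=C(N/N=C/c1ccc([N+](=O)[O-])cc1)Nc1cc2c(Nc3ccc(F)c(Cl)c3)ncnc2cc1O[C@H]1CCOC1`: 35300 nM
compound 2 `COc1ccc(/C=N/NC(=O)Nc2cc3c(Nc4ccc(F)c(Cl)c4)ncnc3cc2O[C@H]2CCOC2)cc1`: 28800 nM
compound 3 `COc1cc(/C=N/NC(=O)Nc2cc3c(Nc4ccc(F)c(Cl)c4)ncnc3cc2O[C@H]2CCOC2)cc(OC)c1OC`: 31200 nM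

Compound 3, at 31200 nM, cannot be told apart from the other two compounds, as the numbers give a 1.1-fold higher number from compound 2 to compound 3 (0.03 log units; within the scatter) and a 1.1-fold lower number from compound 1 to compound 3 (0.05 log units; within the scatter). The remaining pair gives a 1.2-fold lower number from compound 1 to compound 2 (0.09 log units; within the scatter), so the three values form one flat group in this assay.

Compound 4 `O=C(N/N=C/c1ccc(O)c(Br)c1)Nc1cc2c(Nc3ccc(F)c(Cl)c3)ncnc2cc1O[C@H]1CCOC1` keeps the shared core and changes only the group on a carbon with a double bond to nitrogen: 3-bromo-4-hydroxyphenyl in place of 3,4,5-trimethoxyphenyl on a carbon with a double bond to nitrogen. All three measured steps altered that same aryl group, and none moved the number beyond the scatter. Going by the values given here, none of the measured compounds carries a bromo or hydroxy group, however, so that part of the change remains untested. With a 1.1-fold higher number from compound 2 to compound 3 (0.03 log units; within the scatter) as the closest measured swap, no shift beyond the scatter is expected. The expected change is a 1.1-fold lower number from compound 3 to compound 4 (0.05 log units; within the scatter). For compound 4 the estimated value is 28000 nM, with an expected range from 12000 nM to 55000 nM.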

Compound 4, half-maximal inhibitory concentration: 660 nM
Estimate against measurement, compound 4: 42-fold (1.63 log units) above; the whole stated range lies above it.
By their numbers in this assay, from the lowest: compound 4; then compounds 2, 3 and 1 (each within the scatter of the next).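

In this assay, the group on the carbon with a double bond to nitrogen turns out not to be a silent position: the three earlier aryl groups had stayed within the scatter of one another, whereas 3-bromo-4-hydroxyphenyl gives a large drop in the number against each of them (a 47-fold lower number from compound 3 to compound 4 (1.67 log units; beyond the scatter); a 44-fold lower number from compound 2 to compound 4 (1.64 log units; beyond the scatter); a 53-fold lower number from compound 1 to compound 4 (1.73 log units; beyond the scatter)). The drop is about the same size whichever of the nitro, methoxy or trimethoxy compounds it is read from, and compound 4 alone stands apart from that flat group. Nothing available here accounts for this drop.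

The bromo and hydroxy groups enter together, so the compounds shown cannot say whether either one alone would give this result. They also leave open whether a chloro group could replace the bromo, or an amine the hydroxy.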